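The compounds below may be only part of what the source reports. "The series", "measured", "known", "first", "only" and "open" are said of these compounds alone.

Measured compounds:
compound 1, `C=CCNC(=O)/C(C)=C(/C)c1ccc(OC)cc1`: 400 mg/kg
compound 2, `COc1ccc(/C(C)=C(/C)C(=O)NC2CC2)cc1`: 300 mg/kg
compound 3, `C#CCNC(=O)/C(C)=C(\C)c1ccc(OC)cc1`: 150 mg/kg

In a toxicity assay on the whole organism (strain Icem-CET (SPF Caw)) for cytotoxicity, with Mus musculus as the target (on this read-out higher numbers stand for an effect only at larger amounts of compound and lower numbers for an effect already at smaller amounts), compound 1 gives the highest of the three numbers. Its nearest neighbour is compound 2, and the step of a 1.3-fold lower number from compound 1 to compound 2 (0.12 log units; within the scatter) stays within the scatter, so the two cannot be ordered. Within the data shown here, compound 3 sits furthest from compound 1, and the gap between their values lies beyond the scatter; the two differ in more than one place, so no single step connects them.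

Compound 4, `C=CCNC(=O)/C(C)=C(/C)c1ccc(Cl)cc1`, is not yet measured. It differs from compound 1 by one change: chloro in place of methoxy on an aromatic carbon. Among the measured compounds shown here, the only measured step, from compound 1 to compound 2, concerns the group on the amide-type nitrogen, not the aromatic ring, so no measured step bears on this change. With nothing to point either way, the account expects for compound 4 no step beyond the scatter, that is no change at the digits printed from compound 1 to compound 4 (within the scatter). The estimate for compound 4 in this assay is 400 mg/kg, with a range from 200 mg/kg to 800 mg/kg.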

Compound 4, dose for half-maximal effect: 400 mg/kg
Beside the measured number, compound 4's estimate shows no gap at the digits printed; the measured number falls inside the stated range.
By their numbers in this assay, from the lowest: compounds 3, 2, 1 and 4 (each within the scatter of the next, the first and the last beyond it).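

In this assay the account reads no change at the digits printed from compound 1 to compound 4 (within the scatter) for chloro in place of methoxy on an aromatic carbon, para to a large group. Among these compounds, the earlier compounds varied only at the amide-type nitrogen, so this is the first reading at this ring position, and it shows that, with allyl kept on that nitrogen, the methoxy and its hydrogen-bond acceptor can be exchanged for chloro without a step beyond the scatter. Nothing measured here accounts for this result.

Going by these compounds, whether other groups at this position, such as an amine or a carboxylic acid, would also stay within the scatter remains open. So does whether chloro would read the same with cyclopropyl on the amide-type nitrogen, the group carried by compound 2.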